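Swapping the Formyl Group of Compound 2

The source may report more compounds than this note shows. Statements on the series, on what has been measured and on what is new or still open speak of the compounds shown alone.

Among the measured compounds shown here, in a functional assay on SEM cells (Homo sapiens) for cytotoxicity, with a stated time of 72 h (a higher number here means that more compound is needed for the effect, a lower number that less compound is needed), compound 2 `COc1ccc(/C=C/[C@@](C)(/C=C/c2ccc(O)c(C=O)c2)CCC=C(C)C)cc1` gives 4550 nM and is the only compound with a true number so far. Compound 1 `C=C[C@@](C)(/C=C/c1ccc(O)cc1)CC/C=C/C(=O)c1ccccc1` reads > 36600 nM which is a limit of the assay and not a number. The change 2-(tert-butoxycarbonyl)ethenyl in place of formyl on an aromatic carbon puts 2-(tert-butoxycarbonyl)ethenyl in place of formyl on an aromatic carbon, ortho to a hydroxy group, and gives compound 3 `COc1ccc(/C=C/[C@@](C)(/C=C/c2ccc(O)c(/C=C/C(=O)OC(C)(C)C)c2)CCC=C(C)C)cc1` for testing. For the measured compounds named here, no measured step shows what this swap does in this assay so no step beyond the scatter is expected. The estimated change a 1.3-fold higher number from compound 2 to compound 3 (0.12 log units; within the scatter) stays small. For compound 3 the expected value is 6000 nM with an estimated range from 1800 nM to 18000 nM in this assay.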

Compound 3, half-maximal effective concentration: > 36600 nM
Compound 3 was reported as a limit; the forecaster's own chance of this, stated with the estimate: 10%; middle value at least 6.1-fold (0.78 log units) away from the limit.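

At the aromatic carbon ortho to a hydroxy group, the formyl group cannot be exchanged for 2-(tert-butoxycarbonyl)ethenyl without a clear change in this assay, giving an at least 8.0-fold higher number from compound 2 to compound 3 (0.90 log units; beyond the scatter). Among the compounds shown here, this is the first measured step at this position, and it shows that more compound is needed after this swap. Compound 3 gives > 36600 nM, which is a limit of the assay and not a number, so the full size of the step remains unknown: the limit of > 36600 nM in this assay, at which 2 of the 3 values shown sit.

The compounds shown leave open which part of the new group matters. They also leave open how a smaller group, such as hydroxymethyl, or a free carboxylic acid on the ethenyl chain would read here.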